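Working notes: compound 3 to compound 4 in cytotoxicity

A few compounds are considered here, and "the series" means these few. Any claim that something is new, unique, unknown or untested is made for them only; others in the source may bear on it.

Measured compounds:
- compound 1 `COc1cc2c(cc1OC)C(/C(C)=N/NC(N)=S)N(S(=O)(=O)c1ccc(C)cc1)CC2` gives > 50 ug/mL in a functional assay on A549 cells (Homo sapiens) for cytotoxicity, read by crystal violet staining, with a stated time of 3 days (a higher number here means a weaker inhibitor, a lower number a stronger inhibitor), a limit of the assay.
- compound 2 `COc1cc2c(cc1OC)C(/C(C)=N/NC(N)=S)N(S(=O)(=O)c1ccc([N+](=O)[O-])cc1)CC2` gives > 50 ug/mL in this assay, a limit of the assay.
- compound 3 `C/C(=N\NC(N)=S)C1c2ccccc2CCN1S(=O)(=O)c1ccc(C)cc1` gives > 50 ug/mL in this assay, a limit of the assay.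

Compound 3 stands where the other two stand: at the limit, with no number beneath it. For the measured compounds named here, the one step between measured compounds, a step that the two limits leave unreadable from compound 1 to compound 2, is a nitro in place of methyl on an aromatic carbon, and it cannot be read because both ends are limits. The shared picture is the limit of > 50 ug/mL in this assay, at which 3 of the 3 values shown sit.

Compound 4 `COc1ccc(S(=O)(=O)N2CCc3ccccc3C2/C(C)=N/NC(N)=S)cc1` differs from compound 3 by methoxy in place of methyl on an aromatic carbon. Going by the values given here, no measured step bears on this exchange of methyl for methoxy on an aromatic carbon, and the only measured step is itself unreadable. Nothing in the numbers shown points to a value clear of the limit, so the expectation for compound 4 rests on where compound 3 sits, which is > 50 ug/mL. The expected step from compound 3 to compound 4 is a step that the limit leaves unreadable from compound 3 to compound 4, most likely none that the assay can show. Compound 4 is therefore estimated at 60 ug/mL, in a range from 30 ug/mL to 120 ug/mL, and a limit rather than a number is the more probable report.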

Compound 4, half-maximal inhibitory concentration: > 50 ug/mL
Compound 4 ended at the assay's limit (the forecaster's own chance of this, stated with the estimate: 80%); the middle value does not contradict the limit.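

In this assay, for the compounds shown here, no step from compound 3 to compound 4 can be read, as both values are limits of the assay and not numbers, and the series stays where it stood: the limit of > 50 ug/mL in this assay, at which 4 of the 4 values shown sit. The compounds shown leave open which change to the shared core, if any, would give a value clear of this limit.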